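Pyridine in place of the chlorinated methylphenyl amide

The compounds below may be only part of what the source reports. "The series", "measured", "known", "first", "only" and "open" are said of these compounds alone.

Three amides sharing the core of compound 1 `CS(=O)(=O)c1ccc(C(=O)Nc2ccc(Cl)c(-c3nnc4c(Cl)cccn34)c2)c(Cl)c1` were examined in a functional assay on AN3-CA cells (Homo sapiens) for antiproliferative activity, read by MTT assay, with a stated time of 72 h; on this read-out higher numbers stand for weaker inhibition and lower numbers for stronger inhibition. Compound 1 reaches only the assay limit of > 100000 nM. Compound 2 `Cc1cc(Cl)ccc1C(=O)Nc1ccc(Cl)c(-c2nnc3c(Cl)cccn23)c1` also reaches only the limit of > 100000 nM, so its position is known as a bound rather than a number. Compound 3 `O=C(Nc1ccc(Cl)c(-c2nnc3c(Cl)cccn23)c1)c1ccc(Cl)cc1Cl` gives 84800 nM. The step of an at least 1.1-fold lower number from compound 1 to compound 3 (0.07 log units; that floor lies within the scatter) and the step of an at least 1.1-fold lower number from compound 2 to compound 3 (0.07 log units; that floor lies within the scatter) are floors lying within the scatter, which follows from the limit of > 100000 nM in this assay, at which 2 of the 3 values shown sit. Compound 4 `O=C(Nc1ccc(Cl)c(-c2nnc3c(Cl)cccn23)c1)c1cccnc1` differs from compound 2 by pyridin-3-yl in place of 4-chloro-2-methylphenyl on a carbonyl carbon. Among the measured compounds shown here, no measured step exchanges the whole amide ring, so the two measured steps bear on it only loosely. Compound 4 is expected to stay near the limit, a step of a number no higher from compound 2 to compound 4 (the limit leaves the size open). Compound 4 is estimated at 100000 nM, between 30000 nM and 300000 nM.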

Compound 4, half-maximal inhibitory concentration: > 100000 nM
Compound 4: a limit, no number (the forecaster's own chance of this, stated with the estimate: 70%); the middle value lies on the limit itself.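

With pyridin-3-yl on the carbonyl carbon, compound 4 in this assay also gives only a limit, > 100000 nM, so a ring with a hetero atom at this place yields no measurable value here. The change from 2,4-dichlorophenyl reads as an at least 1.1-fold higher number from compound 3 to compound 4 (0.07 log units; that floor lies within the scatter), while the step from compound 2 cannot be read. The size of the ring change therefore stays unknown because so many values rest on the same limit: the limit of > 100000 nM in this assay, at which 3 of the 4 values shown sit.

From the compounds shown here alone, whether an amine or a carboxylic acid on the amide ring would give a value short of the limit remains open.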